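Simplifying the Amide Aryl Group of Compound 1

A few compounds are considered here, and "the series" means these few. Any claim that something is new, unique, unknown or untested is made for them only; others in the source may bear on it.

Measured compounds:
compound 1, `COc1cc(-c2nn(-c3cccc(NC(=O)c4ccc(Cl)c(C(F)(F)F)c4)c3)cc2-c2ccncc2)ccc1Cl`, > 32500 nM
compound 2, `O=C(Nc1cccc(-n2cc(-c3ccncc3)c(-c3ccc(Cl)c(O)c3)n2)c1)Nc1cc(C(F)(F)F)cc(C(F)(F)F)c1`, 8460 nM
compound 3, `COc1cc(-c2nn(-c3cccc(NC(=O)Nc4cccc(C(F)(F)F)c4)c3)cc2-c2ccncc2)ccc1Cl`, 3480 nM

The three measured compounds share one core and differ only in the group carried on the amide nitrogen at one end. In a functional assay on UACC-62 cells (Homo sapiens) for inhibition, read by sulforhodamine B assay, with a stated time of 48 h (a higher number here means that more compound is tolerated, a lower number that less compound is tolerated), compound 1 stands at the limit of the measurement, > 32500 nM, so only a bound is known for it. Among the compounds with values here, compound 3 gives 3480 nM, and compound 2 gives 8460 nM; no single-change step links compound 2 to the other two. Within the data shown here, the only measured step that touches the same carbonyl carbon is an at least 9.3-fold lower number from compound 1 to compound 3 (0.97 log units; beyond the scatter), and its size is known only as a bound because of the limit of > 32500 nM in this assay, at which 1 of the 3 values shown sits.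

Compound 4, `COc1cc(-c2nn(-c3cccc(NC(=O)c4ccccc4)c3)cc2-c2ccncc2)ccc1Cl`, is not yet measured. It differs from compound 1 by phenyl in place of 4-chloro-3-(trifluoromethyl)phenyl on a carbonyl carbon. Among the measured compounds shown here, the one bearing step also removed the 4-chloro-3-(trifluoromethyl)phenyl and gave a lower number beyond the scatter, but it brought in a different group at the same time, so it is a loose guide. Since compound 1 sits at a limit, compound 4 is expected to stay close to that bound, with an expected step of an at least 1.0-fold lower number from compound 1 to compound 4 (0.03 log units; that floor lies within the scatter). Compound 4 is therefore estimated at 30000 nM, within 8000 nM to 100000 nM, with a real chance that only a limit is reported again.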

Compound 4, concentration lethal to 50% of the cells: > 100000 nM
Compound 4 gave a limit, no number; the forecaster's own chance of this, stated with the estimate: 55%; middle value at least 3.3-fold (0.52 log units) away from the limit.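

In this assay compound 4 gives > 100000 nM, which is a limit of the assay and not a number. On these data alone, compound 1 also ends in a limit, so the step between these two compounds cannot be read, and how far the plain phenyl moves the result from the 4-chloro-3-(trifluoromethyl)phenyl stays unknown. What compound 4 adds is that stripping the chlorine and the trifluoromethyl from the aryl group on the carbonyl carbon does not by itself bring a measurable number, whereas the readable comparison is an at least 28-fold higher number from compound 3 to compound 4 (1.45 log units; beyond the scatter), so the lower number of compound 3 cannot be credited simply to the loss of the 4-chloro-3-(trifluoromethyl)phenyl.

Compound 3 differs from compound 4 in both the amino link on the carbonyl carbon and the trifluoromethyl on the ring, so the two contributions remain tangled. A plain phenylamino group on the carbonyl carbon, or a 3-(trifluoromethyl)phenyl joined directly to it, would separate them and show which of the two carries the lower number.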